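Replacing the pyrrolylphenyl group with an ethoxycarbonylpiperidine

The source may hold more compounds than are shown below. What is called first, only, known or untested is meant among the compounds shown, and "the series" means these compounds.

Of the compounds shown here, three sharing one core have been measured in an ADME assay on Caco-2 cells (Homo sapiens) for permeability, in the apical to basolateral direction; on this read-out lower numbers stand for lower permeability and higher numbers for higher permeability. Compound 1 `Cn1cncc1CN1CC(N(CC2CCN(C(=O)C3CCCC3)CC2)S(=O)(=O)c2ccccn2)Cc2cc(C#N)ccc21` gives 0.5 10^-6 cm/s in this assay, and compound 2 `Cn1cncc1CN1CC(N(CC2CCN(C(=O)c3ccccc3)CC2)S(=O)(=O)c2ccccn2)Cc2cc(C#N)ccc21` gives 0.5 10^-6 cm/s; the step of no change at the digits printed from compound 1 to compound 2 (within the scatter) shows that exchanging the acyl group on the piperidine did nothing within the scatter. Compound 3 `Cn1cncc1CN1CC(N(Cc2cccc(-n3cccc3)c2)S(=O)(=O)c2ccccn2)Cc2cc(C#N)ccc21` gives 2.3 10^-6 cm/s and stands highest of the three, beyond the scatter from both compound 1 and compound 2.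

The next compound, compound 4 `CCOC(=O)N1CCC(CN(C2Cc3cc(C#N)ccc3N(Cc3cncn3C)C2)S(=O)(=O)c2ccccn2)CC1`, differs from compound 3 by 1-(ethoxycarbonyl)piperidin-4-yl in place of 3-(1H-pyrrol-1-yl)phenyl on a saturated chain carbon bound to a sulfonamide nitrogen. Among the measured compounds shown here, no measured step covers this exact exchange. What bears on it is that compound 1 and compound 2, which both carry a piperidin-4-ylmethyl group on the sulfonamide nitrogen, sit well under compound 3, and that the step of no change at the digits printed from compound 1 to compound 2 (within the scatter) shows the group on the piperidine nitrogen to matter little. Compound 4 is therefore expected to fall back toward their level, a step of a 3.3-fold lower number from compound 3 to compound 4 (0.52 log units; beyond the scatter) downward. Compound 4 is estimated at 0.7 10^-6 cm/s, in the range 0.3 10^-6 cm/s to 1.6 10^-6 cm/s.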

Compound 4, apparent permeability: 2.6 10^-6 cm/s
Estimate against measurement, compound 4: 3.7-fold (0.57 log units) below; measured number above the stated range.
By their numbers in this assay, from the lowest: compounds 1 and 2 (each within the scatter of the next); then compounds 3 and 4 (each within the scatter of the next).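

In this assay, the exchange at this place, on a saturated chain carbon bound to a sulfonamide nitrogen, gives a 1.1-fold higher number from compound 3 to compound 4 (0.05 log units; within the scatter) and so shows that a piperidine-bearing group can read level with 3-(1H-pyrrol-1-yl)phenyl. The group on the piperidine nitrogen also proves to count: ethoxy on the carbonyl carbon gives a 5.2-fold higher number from compound 2 to compound 4 (0.72 log units; beyond the scatter) in place of phenyl and a 5.2-fold higher number from compound 1 to compound 4 (0.72 log units; beyond the scatter) in place of cyclopentyl, although no change at the digits printed from compound 1 to compound 2 (within the scatter) had separated neither of those two groups from the other. Nothing at hand accounts for these steps.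

The compounds shown leave open whether this rise belongs to ethoxy alone or would also come with methoxy or tert-butoxy on that carbonyl carbon. They also leave open how a free piperidine amine or a methanesulfonyl group on that nitrogen would read in this assay.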